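This account rests on a few compounds, and the source may have more. Where it says the series, first, only, none or still open, it means among the compounds named here.

Measured compounds:
compound 1, `CC(C)(C)OC(=O)N1CCC(CNc2ccc3nnnc(Nc4cccc(OC(F)(F)F)c4)c3n2)CC1` — > 100000 nM
compound 2, `OCCNc1ccc2nnnc(Nc3cccc(OC(F)(F)F)c3)c2n1` — > 100000 nM

Both compounds were tested in a functional assay on PC-3 cells (Homo sapiens) for antiproliferative activity, read by MTT assay, with a stated time of 96 h; a lower number here means a stronger inhibitor, a higher number a weaker inhibitor. For compound 1 the result is a limit of the assay rather than a number, > 100000 nM. For compound 2 the result is likewise only a limit, > 100000 nM. Among the measured compounds shown here, compound 2 therefore stands at the limit of > 100000 nM in this assay, at which 2 of the 2 values shown sit, with no measured number to anchor it and no step between measured compounds to follow.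

The unmeasured compound 3 is `CCN1CCN(c2ccc3nnnc(Nc4cccc(OC(F)(F)F)c4)c3n2)CC1`. It differs from compound 2 by 4-ethylpiperazin-1-yl in place of (2-hydroxyethyl)amino on an aromatic carbon. The shared core, with its trifluoromethoxy-substituted anilino group, is kept unchanged. For the measured compounds named here, since both compounds tested so far return only a limit in this assay, there is no numerical step to carry over, and the expectation for this change is no shift beyond the scatter. The step from compound 2 to compound 3 that this estimate means is a number no higher from compound 2 to compound 3 (the limit leaves the size open), expected rather than measured. Compound 3 is estimated at 100000 nM in this assay, with a range from 30000 nM to 300000 nM, and most likely again reported only as a limit.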

Compound 3, half-maximal inhibitory concentration: 16900 nM
The estimate for compound 3 lay 5.9-fold (0.77 log units) above the measured number; measured number outside the range, below it.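

Among the compounds shown here, the exchange of (2-hydroxyethyl)amino for 4-ethylpiperazin-1-yl, on the aromatic carbon next to the ring nitrogen, gives an at least 5.9-fold lower number from compound 2 to compound 3 (0.77 log units; beyond the scatter) in this assay, which shows that the group at this position can move the read-out, something the earlier compounds could not show. Compound 3 is the only compound shown with a number rather than a limit, while compound 1 and compound 2 remain at a limit of the assay: the limit of > 100000 nM in this assay, at which 2 of the 3 values shown sit. For the compounds shown here, the change alters several things at once, bringing in a six-membered non-aromatic ring with 2 hetero atoms and removing both hydrogen-bond donors of the departing group, and the single step does not separate these.

On these data alone, it remains open whether the piperazine ring alone carries the step or the ethyl group on it takes part, a question that an unsubstituted piperazine or a morpholine ring at the same carbon would address. As far as these compounds go, it is also open whether the step would hold with a group other than trifluoromethoxy on the anilino ring, such as a nitrile.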